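A few compounds are considered here, and "the series" means these few. Any claim that something is new, unique, unknown or untested is made for them only; others in the source may bear on it.

The study follows a physicochemical assay for solubility, at pH 7.4 (on this read-out lower numbers stand for lower solubility and higher numbers for higher solubility), across a small set of compounds that share one core. Compound 1 `O=C(Nc1ccc(Cl)c(Cl)c1)N1CCCN(c2ncc(C(F)(F)F)cc2Cl)CC1` sits at a limit of this assay, < 0.1 ug/mL, and that is all the measurement tells about it; this is the limit of < 0.1 ug/mL in this assay, at which 1 of the 3 values shown sits. Compound 2 `CC(C)(C)c1cc(NC(=O)N2CCCN(c3ccc(C#N)cn3)CC2)no1` gives 13 ug/mL in this assay. Compound 3 `CC(C)(C)c1ccc2oc(N3CCCN(C(=O)CC4CCCC4)CC3)nc2c1` gives 26 ug/mL, the higher of the two numbers reported, although its gap to compound 2 lies within the scatter of repeated measurements, so the two cannot be ranked against each other. Compound 4 `CC(C)(C)c1ccc2oc(N3CCCN(C(=O)N4CCS(=O)(=O)CC4)CC3)nc2c1` has not yet been measured in this assay. It differs from compound 3 in one place: 1,1-dioxothiomorpholin-4-yl in place of cyclopentylmethyl on a carbonyl carbon. Going by the values given here, no step between two measured compounds covers this change, so the expectation rests on the value of compound 3 alone and on the shape of the change. The step from compound 3 to compound 4 is expected to bring a rise of a 3.1-fold higher number from compound 3 to compound 4 (0.49 log units; beyond the scatter), beyond the scatter. Compound 4 is accordingly estimated at 80 ug/mL, with a range from 25 ug/mL to 250 ug/mL.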

Compound 4, solubility: > 103 ug/mL
Compound 4 gave a limit, no number; the forecaster's own chance of this, stated with the estimate: 5%; at least 1.2-fold (0.10 log units) between middle value and limit.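

Within this assay, this is the only step between compounds that differ in one place, and the exchange on the carbonyl carbon brings an at least 3.9-fold higher number from compound 3 to compound 4 (0.59 log units; beyond the scatter), which sets a floor on the step and not its size. Compound 4 sits at a limit of the read-out and not at a number, so the full height of the step stays out of view: the limit of > 103 ug/mL in this assay, at which 1 of the 4 values shown sits. The step shows that this place can carry a change beyond the scatter, with an entering group that has no net charge and no hydrogen-bond donors.

From the compounds shown here alone, how much of the step belongs to the ring sulfur with its two oxygens, and how much to the ring nitrogen that turns the carbonyl into a urea, stays open. A morpholin-4-yl or a piperidin-1-yl group on the same carbonyl carbon would separate these parts.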